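This account rests on a few compounds, and the source may have more. Where it says the series, first, only, none or still open, it means among the compounds named here.

Compound 3 `Oc1cccc(-c2cc(-c3cccnc3)nc(-c3ccccc3Cl)c2)c1` belongs to a small set of three-substituted pyridine-type cores carrying a hydroxyphenyl group, a 2-chlorophenyl group and a third aromatic ring. In a functional assay on T47D cells (Homo sapiens) for cytotoxicity, read by CCK-8 assay and cell counting, with a stated time of 2 days (a higher number here means a weaker inhibitor, a lower number a stronger inhibitor), compound 3 has no single number: its entry reads "not determined" (no result reported), as no result was reported for it. Two close relatives do have values. In this assay compound 1 `Oc1ccc(-c2cc(-c3cccs3)nc(-c3ccccc3Cl)c2)cc1` gives 5870 nM, and compound 2 `Oc1cccc(-c2cc(-c3ccc(Cl)cc3)nc(-c3cccs3)c2)c1` gives 10500 nM; the gap between these two values lies within the usual scatter of this assay, so neither can be called the stronger of the pair.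

Compound 4 `Oc1cccc(-c2cc(-c3cccs3)nc(-c3ccccc3Cl)c2)c1` differs from compound 3 in one place: thiophen-2-yl in place of pyridin-3-yl on an aromatic carbon. With no number for compound 3, the size and direction of this step cannot be read from the data. What remains is the closely related compound 1, which gives 5870 nM in this assay and differs from compound 4 only in its hydroxyphenyl group. On that basis compound 4 is expected to give 6500 nM, with an estimated range from 2000 nM to 20000 nM.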

Compound 4, half-maximal inhibitory concentration: 3990 nM
Beside the measured number, compound 4's estimate is 1.6-fold (0.21 log units) above it; measured number inside the range.
By their numbers in this assay, from the lowest: compounds 4, 1 and 2 (each within the scatter of the next, the first and the last beyond it).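

Going by these compounds alone, compound 4 gives the first reading of a change on the chlorophenyl group: in this assay, 2-chlorophenyl in place of 4-chlorophenyl gives a 2.6-fold lower number from compound 2 to compound 4 (0.42 log units; beyond the scatter) with the rest of the structure unchanged, a modest step beyond the scatter. The hydroxyphenyl group can now be compared as well, but 3-hydroxyphenyl in place of 4-hydroxyphenyl gives a 1.5-fold lower number from compound 1 to compound 4 (0.17 log units; within the scatter) and stays within the scatter, so this pair shows no clear difference between the two hydroxyl placements. Nothing presented here accounts for either step.

From the compounds shown here alone, the step between compound 3 and compound 4 cannot be read, so the effect of thiophen-2-yl relative to pyridin-3-yl remains unknown. Also open, going by these compounds, is how this position would respond to furan-2-yl, or how the series would respond to an amine or a carboxylic acid in place of the hydroxyl group.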